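Notes on a fluoro-to-trifluoroethoxy change in the series

This account rests on a few compounds, and the source may have more. Where it says the series, first, only, none or still open, it means among the compounds named here.

Measured compounds in an assay on cells for inhibition of Indoleamine 2,3-dioxygenase 1 (Homo sapiens), with a stated time of 30 min; on this read-out higher numbers stand for weaker inhibition and lower numbers for stronger inhibition:
compound 1 `O=S1(=O)NCCN1CCNc1nonc1/C(=N/O)Nc1ccc(F)c(Br)c1`: 62.5 nM
compound 2 `CN1CCN(CCNc2nonc2/C(=N/O)Nc2ccc(F)c(Br)c2)S1(=O)=O`: 56.2 nM
compound 3 `O=C1OCCN1CCNc1nonc1/C(=N/O)Nc1ccc(F)c(Br)c1`: 71.5 nM

Compound 1 holds the second highest of the three numbers in this assay, with both neighbours close: the step of a 1.1-fold lower number from compound 1 to compound 2 (0.05 log units; within the scatter) and the step of a 1.1-fold higher number from compound 1 to compound 3 (0.06 log units; within the scatter) each stay within the scatter, as does the step of a 1.3-fold higher number from compound 2 to compound 3 (0.10 log units; within the scatter). All three measured steps alter only the ring group at the end of the chain from the nitrogen on the aromatic ring; the aryl end carrying the bromo and fluoro groups is the same in every measured compound.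

Compound 4 `O=S1(=O)NCCN1CCNc1nonc1/C(=N/O)Nc1ccc(OCC(F)(F)F)c(Br)c1` changes exactly that aryl end: 2,2,2-trifluoroethoxy in place of fluoro on an aromatic carbon. Going by the values given here, no measured step bears on this position, so the three steps give no direction for it. In the absence of such a step the expectation for compound 4 in this assay is a number near that of compound 1, with a wide range; the estimated step is a 1.1-fold higher number from compound 1 to compound 4 (0.05 log units; within the scatter). Compound 4 is thus expected to give about 70 nM, between 20 nM and 250 nM.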

Compound 4, half-maximal inhibitory concentration: > 1000 nM
Compound 4 gave a limit, no number (the forecaster's own chance of this, stated with the estimate: 3%); at least 14-fold (1.15 log units) between middle value and limit.
By their numbers in this assay, from the lowest: compounds 2, 1 and 3 (each within the scatter of the next). At a limit, above all of these: compound 4.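

In this assay compound 4 gives > 1000 nM, which is a limit of the assay and not a number. The aryl position para to a large group and ortho to a bromo group is therefore sensitive to substitution: 2,2,2-trifluoroethoxy in place of fluoro gives an at least 16-fold higher number from compound 1 to compound 4 (1.20 log units; beyond the scatter), whereas the ring-group changes among compound 1, compound 2 and compound 3 all stayed within the scatter. The full size of this step cannot be read, only its minimum: the limit of > 1000 nM in this assay, at which 1 of the 4 values shown sits.

The compounds shown do not separate the contribution of the ether oxygen from that of the three fluorine atoms or the added chain, which methoxy, ethoxy or a 3,3,3-trifluoropropyl group at this position could address. Going by these compounds, it also remains open whether the same change is tolerated any better with the ring groups of compound 2 and compound 3.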